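This account rests on a few compounds, and the source may have more. Where it says the series, first, only, none or still open, it means among the compounds named here.

Among the measured compounds shown here, compound 1 `COC(=O)C1=C(C)N=C(C)/C(=C(\O)OC)C1c1ccccc1Cl` stands at the low end of the two numbers so far: in a functional assay (muscle tissue) with Cavia porcellus as the target (a higher number here means that more compound is needed for the effect, a lower number that less compound is needed), compound 1 gives 2.19 nM. For the measured compounds named here, compound 2 `COC(=O)C1=C(C)N=C(C)/C(=C(\O)OC)C1c1ccccc1I` gives 46.8 nM in this assay, and the one measured step, a 21-fold higher number from compound 1 to compound 2 (1.33 log units; beyond the scatter), is large. Compound 3 `C=Cc1ccccc1C1C(C(=O)OC)=C(C)N=C(C)/C1=C(\O)OC` is still to be measured in this assay. vinyl in place of chloro on an aromatic carbon The measured step bears on this change only loosely, since both exchanges replace the same chloro on an aromatic carbon. For compound 3 a smaller loss is expected, a 3.2-fold higher number from compound 1 to compound 3 (0.50 log units; beyond the scatter). Compound 3 is therefore estimated at 7 nM, within a range of 2 nM to 25 nM.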

Compound 3, half-maximal effective concentration: 4.47 nM
Compound 3: the middle estimate sits 1.6-fold (0.19 log units) above what was measured; low and high end bracket the measured number.
By their numbers in this assay, from the lowest: compound 1; then compound 3; then compound 2.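

In this assay, vinyl in place of chloro on this aromatic carbon gives a modest step (a 2.0-fold higher number from compound 1 to compound 3 (0.31 log units; beyond the scatter)), while vinyl in place of iodo gives a large one (a 10-fold lower number from compound 2 to compound 3 (1.02 log units; beyond the scatter)). The position therefore accepts a group of two heavy atoms at a modest cost, and across chloro, iodo and vinyl the number does not follow heavy-atom count, since single-atom iodo gives the highest number. No measurement on hand explains this order. Still open, going by these compounds, is how an ethyl group, an amine or a carboxylic acid would read at this position.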